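A few compounds are considered here, and "the series" means these few. Any claim that something is new, unique, unknown or untested is made for them only; others in the source may bear on it.

This account follows a small set of thiosemicarbazones tested in a functional assay on HT-29 cells (Homo sapiens) for antiproliferative activity, read by sulforhodamine B assay, with a stated time of 72 h; a lower number here means a stronger inhibitor, a higher number a weaker inhibitor. For the measured compounds named here, compound 1 `S=C(N/N=C/c1ccc2ccccc2n1)Nc1ccc(Br)cc1` is the only member with a numerical result: in this assay compound 1 gives 54400 nM, which places it among weak inhibitors. Compound 2 `NC(=S)N/N=C/c1cc2cccnc2s1` gives only a limit of the assay, > 100000 nM, and that entry is not a number. The line the limit of > 100000 nM in this assay, at which 1 of the 2 values shown sits, records this limit. Going by the values given here, no pair of measured compounds differs in one place, so no measured step can be described. Compound 3 `S=C(NCc1ccccc1)N/N=C/c1ccc2ccccc2n1` has yet to be measured in this assay. It differs from compound 1 by benzyl in place of 4-bromophenyl on an amide-type nitrogen. Nothing measured here sets a direction for this change, and compound 1 already lies at weak potency. The step of a 1.1-fold higher number from compound 1 to compound 3 (0.04 log units; within the scatter) is therefore expected to stay within the usual scatter. Compound 3 is estimated at 60000 nM, with a range from 20000 nM to 100000 nM.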

Compound 3, half-maximal inhibitory concentration: 75700 nM
Compound 3: middle estimate off by 1.3-fold (0.10 log units), on the low side; the range from low to high includes it.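

For the compounds shown here, on the amide-type nitrogen attached to the thiocarbonyl carbon, benzyl in place of 4-bromophenyl provides the first measured step in this set, and in this assay it reads as a 1.4-fold higher number from compound 1 to compound 3 (0.14 log units; within the scatter). Compound 1 and compound 3 therefore lie within the scatter of each other, so this assay does not tell these two groups apart at this position, and both remain weak inhibitors. Nothing measured here gives a reason for this outcome. From the compounds shown here alone, whether an amine, a carboxylic acid or a longer chain such as phenylpropyl on this nitrogen would move the result beyond the scatter remains open. Going by these compounds, compound 2 differs from compound 1 in more than one place, so it adds nothing about this position, and the role of the shared core also remains open.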